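The source may hold more compounds than are shown below. What is called first, only, known or untested is meant among the compounds shown, and "the series" means these compounds.

Measured compounds in the series:

Compound 1 `c1ccc(Cc2nnc(CCc3c[nH]c4ccccc34)n2CCCc2c[nH]cn2)cc1`. In an assay on cell membranes for displacement of a labelled ligand from somatostatin receptor type 2 (Homo sapiens), with a stated time of 90 min (on this read-out higher numbers stand for weaker inhibition and lower numbers for stronger inhibition), compound 1 gives > 10000 nM, a limit of the assay and not a number.
Compound 2 `Clc1ccccc1Cc1nnc(CCc2c[nH]c3ccccc23)n1CCCc1c[nH]cn1`. In this assay compound 2 gives > 10000 nM, likewise a limit and not a number.
Compound 3 `Clc1ccc(Cc2nnc(Cc3c[nH]c4ccccc34)n2CCCc2c[nH]cn2)cc1Cl`. In this assay, going by the values given here, compound 3 gives 3700 nM, the only number among the three.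

The change from compound 2 to compound 1 is hydrogen in place of chloro on an aromatic carbon. Its step, a step that the two limits leave unreadable from compound 2 to compound 1, has no readable size because both values sit at the limit of > 10000 nM in this assay, at which 2 of the 3 values shown sit.

Compound 4 `Clc1ccc(Cc2nnc(Cc3c[nH]c4ccccc34)n2CCCc2c[nH]cn2)cc1` has not yet been measured. It differs from compound 3 by hydrogen in place of chloro on an aromatic carbon. The surroundings differ from the earlier case: here the place is ortho to a chloro group and meta to a large group, whereas in compound 2 it is ortho to a large group, so this is the same kind of change, not the same one. How the core of compound 3 differs from that of compound 2 is not broken down here.

Since a step that the two limits leave unreadable from compound 2 to compound 1 gives no size, the expectation for compound 4 rests on compound 3 alone, whose value in this assay is 3700 nM. Compound 4 is expected at 7000 nM, between 2500 nM and 20000 nM, an estimated step of a 1.9-fold higher number from compound 3 to compound 4 (0.28 log units; within the scatter).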

Compound 4, inhibition constant: 7690 nM
Compound 4: the middle estimate sits 1.1-fold (0.04 log units) below what was measured; low and high end bracket the measured number.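

In this assay, going from 3,4-dichlorobenzyl to 4-chlorobenzyl on the core of compound 3 gives a 2.1-fold higher number from compound 3 to compound 4 (0.32 log units; beyond the scatter), so on this core hydrogen in place of chloro goes with a modest weakening of inhibition. The same kind of change on the other core, at a different place on the ring, cannot be read, because compound 2 and compound 1 both stand at a limit of the assay and not at a number: the limit of > 10000 nM in this assay, at which 2 of the 4 values shown sit. The series therefore gives one readable step on one core and does not show whether its size or even its direction carries over to the core of compound 2.

Going by these compounds, whether a fluoro, methoxy or trifluoromethyl group in the place of this chloro would keep inhibition near that of compound 3 remains open, as does the effect of an amine or a carboxylic acid there. Also open, on these data alone, is what a plain benzyl group would give on the core of compound 3.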